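This account rests on a few compounds, and the source may have more. Where it says the series, first, only, none or still open, it means among the compounds named here.

Of the compounds shown here, two measured so far share one core and differ only in the group on one aromatic carbon. Compound 1 `CSc1ccc(COCC#CC(O)c2ccc(F)cc2)cc1` carries a fluoro there, and in a functional assay on HepG2 cells (Homo sapiens) for inhibition, read by MTT assay, with a stated time of 48 h (on this read-out lower numbers stand for stronger inhibition of growth and higher numbers for weaker inhibition of growth), compound 1 gives 31000 nM. Compound 2 `CSc1ccc(COCC#CC(O)c2ccc(C(C)C)cc2)cc1` carries an isopropyl in the same place, and in this assay compound 2 gives 22000 nM. The step of a 1.4-fold lower number from compound 1 to compound 2 (0.15 log units; within the scatter) is too small to count as a real change. For the measured compounds named here, compound 2 thus holds the lowest of the two numbers, yet its only neighbour, compound 1, lies within the scatter, so the two cannot be ranked.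

Compound 3 `CSc1ccc(COCC#CC(O)c2ccc(C#N)cc2)cc1` has not been measured in this assay. It differs from compound 2 by cyano in place of isopropyl on an aromatic carbon. Going by the values given here, the only measured step at this place, a 1.4-fold lower number from compound 1 to compound 2 (0.15 log units; within the scatter), exchanged two groups without moving the number beyond the scatter, and no measured compound carries a cyano, so nothing points to a shift in either direction. For compound 3 the expected step is a 1.3-fold higher number from compound 2 to compound 3 (0.10 log units; within the scatter), meaning no movement beyond the scatter is expected. Compound 3 is therefore estimated at 28000 nM in this assay, with an expected range from 9000 nM to 90000 nM.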

Compound 3, concentration for 50% growth inhibition: 54000 nM
Estimate against measurement, compound 3: 1.9-fold (0.29 log units) below; measured number inside the range.
By their numbers in this assay, from the lowest: compounds 2, 1 and 3 (each within the scatter of the next, the first and the last beyond it).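

Cyano in place of isopropyl gives a 2.5-fold higher number from compound 2 to compound 3 (0.39 log units; beyond the scatter) in this assay and is the first step at this position that lies beyond the scatter, though it is modest, so the group on this aromatic carbon can shift the number. Cyano in place of fluoro gives a 1.7-fold higher number from compound 1 to compound 3 (0.24 log units; within the scatter) and stays within the scatter, so compound 3 can be told apart from compound 2 but not from compound 1, and compound 1 cannot be told apart from either of the others. Nothing available accounts for the gap between the isopropyl and cyano compounds.

The compounds shown leave open how an amine, a carboxylic acid or a longer chain on this aromatic carbon would read, and whether any group here could give a much lower number than compound 2 does. Compound 2 gives 22000 nM, which still sits in the same broad range as the others. Going by these compounds, all of them also share one core, so it remains open whether the exchange of isopropyl for cyano would produce a similar step on a different core.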